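The compounds below may be only part of what the source reports. "The series", "measured", "known", "first", "only" and "open" are said of these compounds alone.

Three compounds have been measured in a functional assay on MCF7 cells (Homo sapiens) for cytotoxicity, read by MTT assay, with a stated time of 48 h; a higher number here means a weaker inhibitor, a lower number a stronger inhibitor:

compound 1 `CCCCCCCCNC(=O)[C@@H](NC(=O)/C=C/c1ccccc1)[C@@H](C)O` gives 35100 nM
compound 2 `C/C=C/C=C/C(=O)N[C@H](C(=O)NCCCCCCCC)[C@@H](C)O` gives 149000 nM
compound 3 `CCCCCCCCCCCCCCNC(=O)[C@@H](NC(=O)/C=C/c1ccccc1)[C@@H](C)O` gives 64600 nM

Compound 4 `C/C=C/C=C/C(=O)N[C@H](C(=O)NCCCCCCCCCCCCCC)[C@@H](C)O` has not yet been measured in this assay. It differs from compound 3 by prop-1-en-1-yl in place of phenyl on a double-bonded chain carbon bound to a double-bonded chain carbon. The same change has already been made once among these compounds, from compound 1 to compound 2, where it reads prop-1-en-1-yl in place of phenyl on a double-bonded chain carbon bound to a double-bonded chain carbon and produced a 4.2-fold higher number from compound 1 to compound 2 (0.63 log units; beyond the scatter). The two cores on which the change is made differ by hexyl in place of hydrogen on a saturated chain carbon, eight bonds along the chain from an amide-type nitrogen; that step, read as a 1.8-fold higher number from compound 1 to compound 3 (0.26 log units; within the scatter), stays within the scatter. The place of the change is the same in both pairs, so this is the same kind of change made on a core that differs only by the chain described. On that ground the step from compound 3 to compound 4 is expected to be a 3.9-fold higher number from compound 3 to compound 4 (0.59 log units; beyond the scatter), resting on a 4.2-fold higher number from compound 1 to compound 2 (0.63 log units; beyond the scatter). Compound 4 is therefore estimated at 250000 nM, with a likely range from 100000 nM to 650000 nM.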

Compound 4, half-maximal inhibitory concentration: 27800 nM
Compound 4: middle estimate off by 9.0-fold (0.95 log units), on the high side; measured number below the stated range.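

In this assay, prop-1-en-1-yl in place of phenyl gave a 2.3-fold lower number from compound 3 to compound 4 (0.37 log units; beyond the scatter), so the change did not carry over from one core to the other with the same direction or size: the same change on two cores in this assay, a 4.2-fold higher number (0.63 log units; beyond the scatter) from compound 1 to compound 2 and a 2.3-fold lower number (0.37 log units; beyond the scatter) from compound 3 to compound 4, 9.9-fold (0.99 log units) apart, beyond the scatter of two such steps. Read the other way, hexyl in place of hydrogen gave a 5.4-fold lower number from compound 2 to compound 4 (0.73 log units; beyond the scatter), and this too depended on the core: the same change on two cores in this assay, a 1.8-fold higher number (0.26 log units; within the scatter) from compound 1 to compound 3 and a 5.4-fold lower number (0.73 log units; beyond the scatter) from compound 2 to compound 4, 9.9-fold (0.99 log units) apart, beyond the scatter of two such steps. Across these four compounds, the two changes therefore do not act independently, but a single set of four cannot show why, or whether the reversal extends to other cores.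

The compounds shown leave open how a decyl chain would behave with either group. They also leave open what an amine or a carboxylic acid on the chain would do.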